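Swapping the thiadiazole arm for a triazole arm

The compounds below may be only part of what the source reports. "The series", "measured", "known", "first", "only" and "open" are said of these compounds alone.

The three measured compounds share a core and differ in two arms. Compound 1 `Cn1cnnc1SCC(=O)N/N=c1/scc(-c2ccc(C#N)cc2)n1-c1ccccc1` carries a cyano group and in an ADME assay on NIH3T3 cells (Mus musculus) for cytotoxicity, read by MTT assay, with a stated time of 24 h (on this read-out lower numbers stand for stronger inhibition and higher numbers for weaker inhibition), compound 1 gives 153 ug/mL. For the measured compounds named here, compound 2 `Cn1cnnc1SCC(=O)N/N=c1/scc(-c2ccc([N+](=O)[O-])cc2)n1-c1ccccc1` carries a nitro group, and in this assay compound 2 gives 133 ug/mL; the one step between them, a 1.2-fold lower number from compound 1 to compound 2 (0.06 log units; within the scatter), is within the scatter. Compound 3 `Cc1nnc(SCC(=O)N/N=c2/scc(-c3ccc(Cl)cc3)n2-c2ccccc2)s1` carries a chloro group together with a 5-methyl-1,3,4-thiadiazol-2-yl on the sulfur, and in this assay compound 3 gives 253 ug/mL. Against compounds 1 and 2, compound 3 stands within the scatter of both, so the three numbers cannot be told apart.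

Compound 4 `Cn1cnnc1SCC(=O)N/N=c1/scc(-c2ccc(Cl)cc2)n1-c1ccccc1` keeps the chloro group of compound 3 and changes the arm on the sulfur: 4-methyl-4H-1,2,4-triazol-3-yl in place of 5-methyl-1,3,4-thiadiazol-2-yl on a sulfur. Going by the values given here, no measured step covers this exchange; the only measured step, from compound 1 to compound 2, concerns a different place and was within the scatter. Compounds 1 and 2 already hold the 4-methyl-4H-1,2,4-triazol-3-yl arm, and their numbers sit within the scatter of compound 3. Compound 4 is therefore expected to show no step beyond the scatter, a 1.4-fold lower number from compound 3 to compound 4 (0.15 log units; within the scatter). The estimate for compound 4 in this assay is 180 ug/mL, with a range from 90 ug/mL to 360 ug/mL.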

Compound 4, half-maximal inhibitory concentration: 51.7 ug/mL
Compound 4: middle estimate off by 3.5-fold (0.54 log units), on the high side, outside the stated range (below it).
By their numbers in this assay, from the lowest: compound 4; then compounds 2, 1 and 3 (each within the scatter of the next).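

In this assay, for the compounds shown here, the sulfur position proves sensitive: 4-methyl-4H-1,2,4-triazol-3-yl in place of 5-methyl-1,3,4-thiadiazol-2-yl, with the chloro group held, gives a 4.9-fold lower number from compound 3 to compound 4 (0.69 log units; beyond the scatter) and this is the first change at this position to be read, though the two arms have the same count of heavy atoms, hydrogen-bond donors and acceptors. The aromatic carbon also proves sensitive once chloro enters, since with the 4-methyl-4H-1,2,4-triazol-3-yl arm held, chloro in place of nitro gives a 2.6-fold lower number from compound 2 to compound 4 (0.41 log units; beyond the scatter) and chloro in place of cyano gives a 3.0-fold lower number from compound 1 to compound 4 (0.47 log units; beyond the scatter) whereas nitro and cyano alone had not been told apart. The data shown offer no measurement that would account for either change.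

From the compounds shown here alone, compound 3 alone carries the 5-methyl-1,3,4-thiadiazol-2-yl arm, so whether chloro would stand apart from nitro or cyano with that arm remains open. Also open, going by these compounds, is how the number would move with an amine or a methoxy group in place of chloro on the aromatic carbon, or with a carboxylic acid on the arm attached to the sulfur.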